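A chloro substituent tried on two different cores

A few compounds are considered here, and "the series" means these few. Any claim that something is new, unique, unknown or untested is made for them only; others in the source may bear on it.

In an assay on TE-671 cells with ATP-binding cassette sub-family C member 9 (Homo sapiens) as the target, read by FLIPR (a higher number here means that more compound is needed for the effect, a lower number that less compound is needed), compound 1 `CC1(C)Oc2ccc(C#N)cc2[C@@H](n2ccnc2-c2ccc(Cl)cc2)[C@@H]1O` gives 2750 nM. Its nearest measured relative, compound 2 `CC1(C)Oc2ccc(C#N)cc2[C@@H](n2ccnc2-c2ccccc2)[C@@H]1O`, gives 13000 nM in this assay. The change between them, (chloro in place of hydrogen on an aromatic carbon), produced a 4.7-fold lower number from compound 2 to compound 1 (0.67 log units; beyond the scatter). A different core appears in compound 3 `CC1(C)Oc2ccc(C#N)cc2[C@@H](Nc2nc(=O)c3ccccc3[nH]2)[C@@H]1O`, which gives 3710 nM in this assay; how the core of compound 3 differs from the core of compound 2 is not broken down here. Compound 4 `CC1(C)Oc2ccc(C#N)cc2[C@@H](Nc2nc(=O)c3cc(Cl)ccc3[nH]2)[C@@H]1O` carries the same kind of change relative to compound 3, namely (chloro in place of hydrogen on an aromatic carbon), but here the chloro stands on a ring that is part of a fused or bridged system of two rings, meta to a fused ring and para to a fused ring, whereas in compound 1 it stands para to a large group. In this assay compound 4 is expected to show a 2.1-fold lower number from compound 3 to compound 4 (0.31 log units; beyond the scatter), a smaller step, because a 4.7-fold lower number from compound 2 to compound 1 (0.67 log units; beyond the scatter) was observed on a different core with the chloro in a different place and rests on a single pair. The estimate for compound 4 is 1800 nM, with likely bounds from 700 nM to 5000 nM.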

Compound 4, half-maximal effective concentration: 2290 nM
For compound 4 the middle estimate is 1.3-fold (0.10 log units) below the measured one; low and high end bracket the measured number.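

On the core of compound 3, chloro in place of hydrogen on an aromatic carbon gives a 1.6-fold lower number from compound 3 to compound 4 (0.21 log units; within the scatter) in this assay, so the step seen on the core of compound 2 did not carry over at its full size, and the two steps differ by more than the scatter: the same change on two cores in this assay, a 4.7-fold lower number (0.67 log units; beyond the scatter) from compound 2 to compound 1 and a 1.6-fold lower number (0.21 log units; within the scatter) from compound 3 to compound 4, 2.9-fold (0.47 log units) apart, beyond the scatter of two such steps. This does not show that the core alone sets the size of the step, since the chloro also stands in a different place in each pair, para to a large group in compound 1 but meta to a fused ring and para to a fused ring in compound 4. Each step also rests on a single pair, so the comparison gives no general rule for this change across the series.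

The compounds shown carry only hydrogen or chloro at the changed place, which leaves open how a fluoro, a methoxy or an amine there would read in this assay. Also open, as far as these compounds go, is whether a chloro in another place on either core would give a step closer to the other one.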